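Chloromethylbenzyl purines: second chloro on the core

A few compounds are considered here, and "the series" means these few. Any claim that something is new, unique, unknown or untested is made for them only; others in the source may bear on it.

Measured so far:
compound 1 `ClCc1ccc(Cn2cnc3c(Cl)ncnc32)cc1` — 4670 nM
compound 2 `ClCc1cccc(Cn2cnc3c(Cl)nc(Cl)nc32)c1` — 3980 nM

In a functional assay on TK-10 cells (Homo sapiens) for cytotoxicity, read by sulforhodamine B assay, with a stated time of 48 h (on this read-out higher numbers stand for weaker inhibition of growth and lower numbers for stronger inhibition of growth), compound 1 gives 4670 nM, the highest of the two numbers; compound 2 gives 3980 nM, and the two values lie within the scatter of each other, so no order between them is claimed. Compound 3 `ClCc1ccc(Cn2cnc3c(Cl)nc(Cl)nc32)cc1` has not yet been measured. It differs from compound 1 by chloro in place of hydrogen on an aromatic carbon. Within the data shown here, no step between measured compounds is available for this change. The expectation is that the step of a 1.1-fold lower number from compound 1 to compound 3 (0.05 log units; within the scatter) stays small, with no direction beyond the scatter, since compound 2 with its own second chloro gives 3980 nM. Compound 3 is estimated at 4200 nM with a range of 2000 nM to 9000 nM.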

Compound 3, concentration for total growth inhibition: 20400 nM
The estimate for compound 3 lay 4.9-fold (0.69 log units) below the measured number, and the stated range ends below it.
By their numbers in this assay, from the lowest: compounds 2 and 1 (each within the scatter of the next); then compound 3.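

In this assay the position between two ring nitrogen atoms is not neutral: chloro in place of hydrogen there gives a 4.4-fold higher number from compound 1 to compound 3 (0.64 log units; beyond the scatter) and so weaker inhibition of growth. This single step reads the change only with the chloromethyl group as placed in compound 1 and compound 3. Nothing on hand bears on why the number rises.

From the compounds shown here alone, whether an amine or a methoxy group at this position would go the same way as chloro stays open. Also open, going by these compounds, is whether hydrogen in place of this chloro on compound 2 would give a similar step.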